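The compounds below may be only part of what the source reports. "The series", "measured", "known", "first", "only" and "open" are said of these compounds alone.

Compound 1 `Cc1cccc(-c2noc(C3CN(S(=O)(=O)c4ccc(Cl)cc4)C3)n2)c1` in an assay on HEK293 cells for negative allosteric modulation of metabotropic glutamate receptor 5 (Homo sapiens), read by FLIPR (on this read-out higher numbers stand for weaker inhibition and lower numbers for stronger inhibition), gives 1100 nM. Compound 3 `Cc1ccc(S(=O)(=O)N2CC(c3nc(-c4cccc(Cl)c4)no3)C2)cc1` in this assay gives 920 nM. Compound 2 `O=C(C1CCC2(CCC2)CC1)N1CC(c2nc(-c3cccc(Cl)c3)no2)C1` in this assay gives > 10000 nM.

The value for compound 2 is a limit of the assay, not a number; compound 2 sits at the limit of > 10000 nM in this assay, at which 1 of the 3 values shown sits, while compound 1 and compound 3 both give measured numbers. Among the measured compounds shown here, no pair of these three differs in one place only, so no single step can be read off. Compound 4 `O=C(c1cccc(F)c1)N1CC(c2nc(-c3cccc(Cl)c3)no2)C1` differs from compound 2 by a group of 7 heavy atoms (6 carbon, 1 fluorine; one six-membered aromatic ring of carbon only) in place of a group of 9 heavy atoms (9 carbon; one four-membered non-aromatic ring of carbon only, one six-membered non-aromatic ring of carbon only), on a carbonyl carbon. Since compound 2 is only known as a limit, the step expected from compound 2 to compound 4 in this assay, an at least 3.3-fold lower number from compound 2 to compound 4 (0.52 log units; beyond the scatter), is itself uncertain, but it is expected to run towards stronger inhibition. Compound 4 is estimated at 3000 nM, with a range from 700 nM to 12000 nM.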

Compound 4, half-maximal inhibitory concentration: 780 nM
For compound 4 the middle estimate is 3.8-fold (0.59 log units) above the measured one; the measured number falls inside the stated range.
By their numbers in this assay, from the lowest: compounds 4, 3 and 1 (each within the scatter of the next). At a limit, above all of these: compound 2.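

The step at this place, the carbonyl carbon bound to the amide-type nitrogen in a ring, is the first that can be read among these compounds: replacing the group with a four-membered and a six-membered non-aromatic ring by 3-fluorophenyl gives an at least 12-fold lower number from compound 2 to compound 4 (1.10 log units; beyond the scatter). So the group on this carbonyl carbon matters for inhibition. The value of compound 2 is a limit, not a number: the limit of > 10000 nM in this assay, at which 1 of the 4 values shown sits.

As far as these compounds go, how an unsubstituted phenyl or a pyridine ring on this carbonyl carbon would compare stays open. From the compounds shown here alone, the share of the fluorine in this step therefore remains unknown.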